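This account rests on a few compounds, and the source may have more. Where it says the series, first, only, none or still open, it means among the compounds named here.

Working notes on the series. Of the compounds shown here, two have been measured so far, both built on one shared core. Compound 1 `CN1CCN(c2nc(N)nc(Cc3ccc(Cl)cc3)n2)CC1` in an assay on HEK293 cells for displacement of a labelled ligand from 5-hydroxytryptamine receptor 6 (Homo sapiens) (a lower number here means a stronger inhibitor, a higher number a weaker inhibitor), gives 52 nM. Compound 2 `CN1CCN(c2nc(N)nc(Cc3ccc(F)cc3)n2)CC1` in this assay gives 100 nM. Among the compounds with values here, compound 2 is one of only two numbers, and its nearest neighbour is compound 1, whose value lies within the scatter of it: the step of a 1.9-fold higher number from compound 1 to compound 2 (0.28 log units; within the scatter) does not separate the two, so neither can be ranked above the other.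

Compound 3 `Cc1cccc(Cc2nc(N)nc(N3CCN(C)CC3)n2)c1` is not yet measured. It differs from compound 2 by 3-methylphenyl in place of 4-fluorophenyl on a saturated chain carbon bound to an aromatic carbon. Within the data shown here, the single measured step that bears on this place, a 1.9-fold higher number from compound 1 to compound 2 (0.28 log units; within the scatter), exchanged one halogen for another on the ring held by the saturated chain carbon and stayed within the scatter. No measured compound carries a 3-methylphenyl group, so that part of the change has no precedent here and the estimate rests on the tolerance the ring has shown so far.

On that basis compound 3 is expected to move by a 1.2-fold higher number from compound 2 to compound 3 (0.08 log units; within the scatter), a step not beyond the scatter. Compound 3 is estimated in this assay at 120 nM, with a range from 35 nM to 400 nM.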

Compound 3, inhibition constant: 30 nM
Estimate against measurement, compound 3: 4.0-fold (0.60 log units) above; the measured number lies below the stated range.
By their numbers in this assay, from the lowest: compounds 3, 1 and 2 (each within the scatter of the next, the first and the last beyond it).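

In this assay, the ring on the saturated chain carbon now shows a change beyond the scatter: a 3.3-fold lower number from compound 2 to compound 3 (0.52 log units; beyond the scatter), with 3-methylphenyl in place of 4-fluorophenyl, whereas the exchange of one halogen for another had separated nothing. Against the chloro compound the same group gives a 1.7-fold lower number from compound 1 to compound 3 (0.24 log units; within the scatter), which is within the scatter, so compound 3 and compound 1 cannot be ranked, and a ring carrying no halogen at all holds a value in the same range as the 4-chlorophenyl ring. Nothing measured on these compounds accounts for the step from the 4-fluorophenyl ring to the 3-methylphenyl ring.

The compounds shown cannot tell whether that step comes from the methyl group itself or from where it sits, a question that a 4-methylphenyl or a 3-fluorophenyl compound would separate. Also open, going by these compounds, is how this ring responds to a group of another kind, such as a methoxy group, an amine or a carboxylic acid, since only halogens and a methyl group have been seen on it here.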